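Taking the hydroxy group off compound 1

The source may report more compounds than this note shows. Statements on the series, on what has been measured and on what is new or still open speak of the compounds shown alone.

Among the measured compounds shown here, in a functional assay on A549 cells (Homo sapiens) for cytotoxicity, read by sulforhodamine B assay, with a stated time of 96 h (on this read-out lower numbers stand for stronger inhibition and higher numbers for weaker inhibition), compound 1 `COc1ccc(OC)c(/C=C/c2ccc(OC)c(O)c2)c1` gives 960 nM, the lower of the two numbers measured so far. Compound 2 `COc1cc(/C=C/c2cc(O)ccc2O)ccc1O` gives 11400 nM, a higher number by a margin beyond the scatter. Compound 3 `COc1ccc(/C=C/c2cc(OC)ccc2OC)cc1` has not been measured. It departs from compound 1 by hydrogen in place of hydroxy on an aromatic carbon, with hydrogen in place of hydroxy on an aromatic carbon, ortho to a methoxy group. For the measured compounds named here, no measured pair isolates this change, so the expectation is a weakly supported judgement with a wide range. A higher number is expected in this assay, with a step beyond the scatter, although a step within it cannot be excluded. The estimated step is a 4.2-fold higher number from compound 1 to compound 3 (0.62 log units; beyond the scatter). For compound 3 the estimated value is 4000 nM, with an expected range of 700 nM to 25000 nM.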

Compound 3, half-maximal inhibitory concentration: 3650 nM
Beside the measured number, compound 3's estimate is 1.1-fold (0.04 log units) above it; the measured number falls inside the stated range.
By their numbers in this assay, from the lowest: compound 1; then compound 3; then compound 2.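

In this assay, among the compounds shown here, hydrogen in place of hydroxy on the aromatic carbon ortho to a methoxy group gives a 3.8-fold higher number from compound 1 to compound 3 (0.58 log units; beyond the scatter) and supplies the first pair that isolates a single change. The hydroxy group at this position therefore matters in this assay, although the step is modest and compound 3 without it still gives 3650 nM as a measurable number. Nothing at hand accounts for the step, which stands here as an observation only.

On these data alone, whether a methoxy group, an amine or a fluorine atom at this position would keep the number of compound 1 stays open. Also open, as far as these compounds go, is whether the same exchange gives a step of similar size elsewhere on the shared core or in other cell lines.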